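A diethylcarbamoyl group on the shared core

This account rests on a few compounds, and the source may have more. Where it says the series, first, only, none or still open, it means among the compounds named here.

In a functional assay on MCF7 cells (Homo sapiens) for antiproliferative activity, read by MTT assay, with a stated time of 48 h (a lower number here means a stronger inhibitor, a higher number a weaker inhibitor), compound 1 (`CC(C)=CCC[C@]1(C)/C=C/[C@@H](OC(=O)C=C(C)C)[C@](C)(O)/C=C/C(=O)/C(CCl)=C\C1`) gives 610 nM on the shared core, compound 2 (`COCOC/C1=C/C[C@](C)(CCC=C(C)C)/C=C/[C@@H](OC(=O)C=C(C)C)[C@](C)(O)/C=C/C1=O`) gives 3120 nM and compound 3 (`CSC(=S)OC/C1=C/C[C@](C)(CCC=C(C)C)/C=C/[C@@H](OC(=O)C=C(C)C)[C@](C)(O)/C=C/C1=O`) gives 900 nM in the same read-out. Two steps fix the place of the last of these: one is a 1.5-fold higher number from compound 1 to compound 3 (0.17 log units; within the scatter) and the other is a 3.5-fold lower number from compound 2 to compound 3 (0.54 log units; beyond the scatter) so the third compound sits level with the first and apart from the second.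

Compound 4 (`CCN(CC)C(=O)/C1=C/C[C@](C)(CCC=C(C)C)/C=C/[C@@H](OC(=O)C=C(C)C)[C@](C)(O)/C=C/C1=O`) carries a group of 7 heavy atoms (5 carbon, 1 nitrogen, 1 oxygen; no ring) in place of a group of 6 heavy atoms (3 carbon, 1 oxygen, 2 sulfur; no ring), on a double-bonded ring carbon in the change from compound 3. The entering group is diethylcarbamoyl. It stands on a double-bonded ring carbon, whereas the varied groups of the three measured compounds stand on a saturated chain carbon bound to a double-bonded ring carbon. Within the data shown here, no measured compound carries an amide, so no step covers this change directly. Among the measured compounds shown here, the closest guide is the only step away from compound 1 that goes beyond the scatter, a 5.1-fold higher number from compound 1 to compound 2 (0.71 log units; beyond the scatter) and it runs upward, while a 3.5-fold lower number from compound 2 to compound 3 (0.54 log units; beyond the scatter) shows that replacing one such group with another can move the number by a modest amount. A modest rise is therefore expected in this assay with no firm support. The estimated step is a 2.8-fold higher number from compound 3 to compound 4 (0.44 log units; beyond the scatter) and remains uncertain. For compound 4 an estimated 2500 nM is expected, with 800 nM to 8000 nM as the expected range.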

Compound 4, half-maximal inhibitory concentration: 12100 nM
The estimate for compound 4 lay 4.8-fold (0.68 log units) below the measured number; measured number above the stated range.
By their numbers in this assay, from the lowest: compounds 1 and 3 (each within the scatter of the next); then compound 2; then compound 4.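

In this assay, diethylcarbamoyl on the double-bonded ring carbon gives the highest number of the four compounds, and its steps from all three others lie beyond the scatter: a 13-fold higher number from compound 3 to compound 4 (1.13 log units; beyond the scatter), a 3.9-fold higher number from compound 2 to compound 4 (0.59 log units; beyond the scatter) and a 20-fold higher number from compound 1 to compound 4 (1.30 log units; beyond the scatter). The earlier compounds shown here all keep a saturated chain carbon on this ring carbon, and the largest step among them is a 5.1-fold higher number from compound 1 to compound 2 (0.71 log units; beyond the scatter), so the position tolerates those chain groups with a smaller shift than it shows when the amide stands directly on the ring. The information shown offers no measured reason for this rise.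

The change from compound 3 to compound 4 removes the saturated chain carbon and brings in the amide together, and the compounds shown leave open which of the two carries the loss. A diethylaminocarbonylmethyl group, with the same amide set one chain carbon away, would help separate them, while a primary carboxamide, a dimethylcarbamoyl group or a carboxylic acid on the ring carbon would show whether the ethyl groups or the carbonyl on the ring matter here.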